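Methoxyphenyl urea in place of benzyl urea

The compounds below may be only part of what the source reports. "The series", "measured", "known", "first", "only" and "open" are said of these compounds alone.

Compound 3 `O=C(NCc1ccccc1)Nc1nn(-c2ccccc2)c(=O)c2ccccc12` gives the lowest number of the three measured compounds in an assay on CHO cells for displacement of a labelled ligand from adenosine receptor A3 (Homo sapiens) (a higher number here means a weaker inhibitor, a lower number a stronger inhibitor), with a value of 29.6 nM. Its nearest neighbour is compound 2 `COc1ccc(NC(=O)Nc2nn(-c3ccccc3)c(=O)c3ccccc23)cc1`, which gives 60.6 nM, and the furthest is compound 1 `O=C(Nc1nn(-c2ccccc2)c(=O)c2ccccc12)c1ccccc1`, the benzamide, which gives 1100 nM. The two urea compounds both sit well away from compound 1: an 18-fold lower number from compound 1 to compound 2 (1.26 log units; beyond the scatter) and a 37-fold lower number from compound 1 to compound 3 (1.57 log units; beyond the scatter), while the difference between the two ureas themselves is smaller, a 2.0-fold lower number from compound 2 to compound 3 (0.31 log units; beyond the scatter).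

Compound 4 `COc1ccccc1NC(=O)Nc1nn(-c2ccccc2)c(=O)c2ccccc12` has not yet been measured in this assay. It differs from compound 3 in one place: 2-methoxyphenyl in place of benzyl on an amide-type nitrogen. Within the data shown here, the step most relevant to this change is the one between compound 2 and compound 3, which moved in the opposite direction to the change now made, since there an aryl on the urea nitrogen gave way to benzyl and the number fell. Among the measured compounds shown here, compound 4 carries a methoxyphenyl on that nitrogen, as compound 2 does, though with the methoxy group in a different position, and no measured step covers that positional change. The expectation is therefore a modest rise in the number for compound 4, a 2.4-fold higher number from compound 3 to compound 4 (0.37 log units; beyond the scatter), an estimate rather than a firm prediction.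

The estimate for compound 4 is 70 nM, with a range from 25 nM to 200 nM.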

Compound 4, inhibition constant: 8.9 nM
The estimate for compound 4 lay 7.9-fold (0.90 log units) above the measured number, and the stated range ends above it.
By their numbers in this assay, from the lowest: compound 4; then compound 3; then compound 2; then compound 1.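

In this assay the exchange of benzyl for 2-methoxyphenyl on the amide-type nitrogen gives a 3.3-fold lower number from compound 3 to compound 4 (0.52 log units; beyond the scatter) and so shows that an aryl group at this place does not always give a higher number than benzyl, as the earlier step from compound 2 to compound 3 alone might have suggested. The place of the methoxy group on the phenyl ring also counts, with 2-methoxyphenyl in place of 4-methoxyphenyl giving a 6.8-fold lower number from compound 2 to compound 4 (0.83 log units; beyond the scatter) and leaving the benzyl urea compound 3 with a number that lies between those of the two methoxyphenyl ureas. Compound 4 also has the lowest number of the series, and its distance from the benzamide is a 120-fold lower number from compound 1 to compound 4 (2.09 log units; beyond the scatter) and thus wider than that of either earlier urea.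

The compounds shown leave open whether the methoxy group itself accounts for the low number of compound 4, a question that a plain phenyl or a hydroxyphenyl group on this nitrogen would bear on. Nothing given here offers a measured explanation for these differences.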